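Shortening the Acyl Chain on a Shared Core

The source may report more compounds than this note shows. Statements on the series, on what has been measured and on what is new or still open speak of the compounds shown alone.

Compound 1 `CC(Nc1nnc2nncn2n1)C(=O)O`: 82200 nM
Compound 2 `CCCCCC(=O)N1CCN(c2nnc3nncn3n2)CC1`: 2960 nM

Of the compounds shown here, two built on a shared core have so far been tested in a functional assay on BeWo cells (Homo sapiens) for inhibition, read by MTT assay, with a stated time of 72 h; a higher number here means a weaker inhibitor, a lower number a stronger inhibitor. In this assay compound 1 gives 82200 nM, while compound 2 gives 2960 nM. For the measured compounds named here, compound 2 stands at the lowest of the two numbers; its only neighbour is compound 1, whose number is higher by a margin well beyond the scatter. No single-change path links the two measured compounds, so only their two values can be compared.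

Compound 3 `CCCCC(=O)N1CCN(c2nnc3nncn3n2)CC1` differs from compound 2 in one place: hydrogen in place of methyl on a saturated chain carbon, four bonds along the chain from a carbonyl carbon. Cut one bond further out, the same difference reads butyl to propyl. Going by the values given here, no step between measured compounds resembles this change, so there is no measured guide to its size. Such a small trimming of a saturated chain is expected to move this assay little, probably not beyond the scatter, with a lean toward a somewhat higher number. Compound 3 is therefore estimated at 4000 nM, with a range from 1800 nM to 9000 nM. The expected step is a 1.4-fold higher number from compound 2 to compound 3 (0.13 log units; within the scatter).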

Compound 3, half-maximal inhibitory concentration: 1720 nM
Compound 3: middle estimate off by 2.3-fold (0.37 log units), on the high side; measured number outside the range, below it.
By their numbers in this assay, from the lowest: compounds 3 and 2 (each within the scatter of the next); then compound 1.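

In this assay the chain now has its first measured step: hydrogen in place of methyl on a saturated chain carbon, four bonds along the chain from a carbonyl carbon, gives a difference that stays within the scatter (a 1.7-fold lower number from compound 2 to compound 3 (0.24 log units; within the scatter)). For the compounds shown here, the earlier compounds offered only two unconnected values, whereas this pair shows that, at this position, removing one methyl from the chain does not produce a difference that can be separated from the scatter, and compound 2 and compound 3 cannot be put in order. No measured property accompanies this result, so the pair gives its size but offers no explanation for it.

One step on one chain cannot show whether the values would stay this close if the chain were changed further, either to a longer chain or to a shorter one such as an ethyl or methyl group. It also leaves open how an amine or a carboxylic acid placed on this chain would read in this assay, since the chains compared here carry neither group.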